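The compounds below may be only part of what the source reports. "The series", "measured", "known", "first", "only" and "open" are said of these compounds alone.

Measured in a functional assay on K562 cells (Homo sapiens), read by MTT assay, with a stated time of 72 h; a lower number here means a stronger inhibitor, a higher number a weaker inhibitor:
- compound 1 `CSc1ncnc2c1c(-c1ccoc1)cn2[C@@H]1O[C@H](CO)[C@@H](O)[C@H]1O`: 3250 nM
- compound 2 `CSc1ncnc2c1c(-c1ccsc1)cn2[C@@H]1O[C@H](CO)[C@@H](O)[C@H]1O`: > 20000 nM, a limit of the assay and not a number
- compound 3 `CNc1ncnc2c1c(-c1ccco1)cn2[C@@H]1O[C@H](CO)[C@@H](O)[C@H]1O`: 15100 nM

Of the two exact numbers, compound 3 holds the higher, at 15100 nM. Compound 4 `CNc1ncnc2c1c(-c1cccs1)cn2[C@@H]1O[C@H](CO)[C@@H](O)[C@H]1O` carries thiophen-2-yl in place of furan-2-yl on an aromatic carbon. Among the measured compounds shown here, the only comparable measured change is thiophen-3-yl in place of furan-3-yl, an at least 6.1-fold higher number from compound 1 to compound 2 (0.78 log units; beyond the scatter). That step ends at the limit of > 20000 nM in this assay, at which 1 of the 3 values shown sits. The attachment differs there, and compound 1 and compound 2 also differ from compound 3 elsewhere, so only its upward direction carries over, and loosely. In this assay, the expected change is a 1.3-fold higher number from compound 3 to compound 4 (0.12 log units; within the scatter). For compound 4 the estimated value is 20000 nM, with an expected range of 7000 nM to 50000 nM.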

Compound 4, half-maximal inhibitory concentration: > 20000 nM
Compound 4 was reported as a limit; the forecaster's own chance of this, stated with the estimate: 50%; the middle value lies on the limit itself.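

In this assay, the swap of furan for thiophen now appears at a second attachment, thiophen-2-yl in place of furan-2-yl, with an at least 1.3-fold higher number from compound 3 to compound 4 (0.12 log units; that floor lies within the scatter). That floor lies within the scatter, so a loss from this change is not established here, unlike the step from furan-3-yl to thiophen-3-yl. Compound 2 and compound 4 both end at one limit, and neither gives a number: the limit of > 20000 nM in this assay, at which 2 of the 4 values shown sit.

From the compounds shown here alone, the true size of either swap remains unknown while these compounds sit at that limit. A phenyl ring or an aminomethyl group at this position remains untested in the compounds shown.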